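This account rests on a few compounds, and the source may have more. Where it says the series, first, only, none or still open, it means among the compounds named here.

Compound 1, `COCC(C)(C)C#Cc1c(Cl)c2c(Cl)cc(C(N)=O)nc2n1[C@H]1CCCNC1`, gives 219 nM in a functional assay on KG-1 cells (Homo sapiens) for antiproliferative activity; a higher number here means that more compound is needed for the effect, a lower number that less compound is needed.
Compound 2, `CC(C)(C#N)CC#Cc1c(Cl)c2c(Cl)cc(C(N)=O)nc2n1[C@H]1CCCNC1`, gives 113 nM in this assay.

These two compounds share one core and differ only in the group attached to the triple-bonded carbon. Going by the values given here, of the two numbers, the one for compound 2 is the smaller, but the step of a 1.9-fold lower number from compound 1 to compound 2 (0.29 log units; within the scatter) lies within the scatter, so the data show no real separation between compound 1 and compound 2.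

Compound 3, `CC(O)C#Cc1c(Cl)c2c(Cl)cc(C(N)=O)nc2n1[C@H]1CCCNC1`, is not yet measured. It differs from compound 2 by 1-hydroxyethyl in place of 2-cyano-2-methylpropyl on a triple-bonded carbon. Among the compounds with values here, the only measured step that touches this position, a 1.9-fold lower number from compound 1 to compound 2 (0.29 log units; within the scatter), exchanged one group for another at the same carbon and stayed within the scatter; neither of those groups carries a hydroxyl, so that step bears only loosely on the present change. Within the data shown here, with no direct precedent, the expectation is a small shift at most. For compound 3 the step of a 1.8-fold higher number from compound 2 to compound 3 (0.25 log units; within the scatter) is expected, a slight rise that need not exceed the scatter. Compound 3 is therefore estimated at 200 nM, with a range from 60 nM to 700 nM.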

Compound 3, half-maximal effective concentration: 147 nM
Beside the measured number, compound 3's estimate is 1.4-fold (0.13 log units) above it, and the stated range covers the measured number.
By their numbers in this assay, from the lowest: compounds 2, 3 and 1 (each within the scatter of the next).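

Replacing 2-cyano-2-methylpropyl with 1-hydroxyethyl removes a nitrile and brings in a hydrogen-bond donor, and the chain falls from 6 heavy atoms to 3, yet the result is a 1.3-fold higher number from compound 2 to compound 3 (0.11 log units; within the scatter) in this assay. Set against the ether-bearing group of compound 1, the same 1-hydroxyethyl group gives a 1.5-fold lower number from compound 1 to compound 3 (0.17 log units; within the scatter), so all three groups on this triple-bonded carbon now lie within the scatter of one another, although they differ in size and in the atoms they carry. The earlier pair could not show that a group with a hydrogen-bond donor also falls within this narrow band, and no accompanying measurement offers an explanation for these numbers.

As far as these compounds go, whether a primary amine, a carboxylic acid or a much longer carbon chain on this triple-bonded carbon would separate clearly from these three compounds remains open. It is also unknown whether these groups would stay this close in any test other than this assay, or whether the same changes would behave alike on a different core.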